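The source may hold more compounds than are shown below. What is called first, only, known or untested is meant among the compounds shown, and "the series" means these compounds.

Measured compounds in an assay on CHO cells for agonist activity at Neuronal acetylcholine receptor; alpha3/alpha6/beta2/beta3 (Homo sapiens), read by FLIPR and calcium flux; on this read-out higher numbers stand for an effect only at larger amounts of compound and lower numbers for an effect already at smaller amounts:
compound 1 `CC(=O)N1CC2CC(C1)N2` gives 750 nM
compound 2 `CC(C)C(=O)N1CC2CC(C1)N2` gives 16000 nM
compound 3 `O=C(C1CC=CC1)N1CC2CC(C1)N2` gives 1900 nM

Compound 2 stands at the highest number of the three in this assay; compound 3 is the nearest and compound 1 the furthest, both beyond the scatter. Among the measured compounds shown here, the only single-place step among the measured compounds is a 21-fold higher number from compound 1 to compound 2 (1.33 log units; beyond the scatter), isopropyl in place of methyl on the carbonyl carbon. For the measured compounds named here, compound 3 carries a ring-bearing group on the same carbonyl carbon and gives a number well below that of compound 2, but no single-place step is drawn between them, so only their two values can be set side by side.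

Compound 4 `C[C@@H]1C[C@@H]1C(=O)N1CC2CC(C1)N2` is the next member. Its change from compound 2 is a group of 4 heavy atoms (4 carbon; one three-membered non-aromatic ring of carbon only) in place of a group of 3 heavy atoms (3 carbon; no ring), on a carbonyl carbon. The change keeps the carbonyl substituent small while introducing a ring, which places compound 4 between the ring-free isopropyl of compound 2 and the larger ring of compound 3 in character. Given the high number of compound 2 and the lower number of compound 3, a lower number for compound 4 in this assay is expected, but the size is uncertain because the only step on record, a 21-fold higher number from compound 1 to compound 2 (1.33 log units; beyond the scatter), concerns a ring-free group. Compound 4 is estimated at 5000 nM, range 1500 nM to 16000 nM, which means an expected step of a 3.2-fold lower number from compound 2 to compound 4 (0.51 log units; beyond the scatter).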

Compound 4, half-maximal effective concentration: 920 nM
Beside the measured number, compound 4's estimate is 5.4-fold (0.74 log units) above it; the whole stated range lies above it.
By their numbers in this assay, from the lowest: compounds 1 and 4 (each within the scatter of the next); then compound 3; then compound 2.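

On the carbonyl carbon whose other neighbours are the amide-type nitrogen in a ring, the number in this assay does not simply rise with the heavy-atom count of the group: the record shows a 17-fold lower number from compound 2 to compound 4 (1.24 log units; beyond the scatter), although the entering group is the larger of the two. Set against the methyl of compound 1, the group of compound 4 gives a 1.2-fold higher number from compound 1 to compound 4 (0.09 log units; within the scatter), so this assay does not separate these two groups, whereas isopropyl stood well apart from methyl. Among these three compounds, growth beyond methyl therefore does not by itself bring a high number, and compound 2 is the only one of the three that carries one. Nothing on record bears on why isopropyl and the three-membered ring part so widely.

On these data alone, it remains open whether a longer chain such as n-butyl, or a group carrying an amine, on the same carbonyl carbon would fall with compound 1 and compound 4 or with compound 2. Also open, as far as these compounds go, is whether the mirror-image form of the group in compound 4, with both defined stereocentres inverted, would give a similar number.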